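The compounds below may be only part of what the source reports. "The series", "measured", "known", "first", "only" and "open" are said of these compounds alone.

Measured compounds:
compound 1, `Cn1c(C(=O)NCc2ccc(S(=O)(=O)c3ccccc3)cc2)cc2cnccc21`: 78%
compound 2, `O=C(NCc1ccc(S(=O)(=O)c2cc(F)cc(F)c2)cc1)c1cc2ccncc2o1`: 77%
compound 3, `O=C(NCc1ccc(S(=O)(=O)N2CCCCC2)cc1)c1cc2cnccc2s1`: 15%

In an ADME assay on microsomes from liver (Homo sapiens) for metabolic stability, read by LC-MS, with a stated time of 30 min, tested at 1 uM (on this read-out higher numbers stand for a more stable compound and lower numbers for a less stable compound), compound 1 gives 78% and compound 2 gives 77%. Compound 3 gives 15%, the lowest of the three numbers; its gap to compound 2, the nearest, and to compound 1, the furthest, both lie beyond the scatter. No pair among these three differs in only one place, so no single change can be tied to that gap.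

Compound 4, `O=C(NCc1ccc(S(=O)(=O)N2CCCCC2)cc1)c1ccn2cncc2c1`, has not yet been measured in this assay. It differs from compound 3 in one place: a group of 9 heavy atoms (7 carbon, 2 nitrogen; one five-membered aromatic ring with 2 hetero atoms, one six-membered aromatic ring with 1 hetero atom) in place of a group of 9 heavy atoms (7 carbon, 1 nitrogen, 1 sulfur; one five-membered aromatic ring with 1 hetero atom, one six-membered aromatic ring with 1 hetero atom), on a carbonyl carbon. The core of compound 3 carries a sulfur atom that the cores of compound 1 and compound 2 lack, and compound 3 is the least stable of the three; the core of compound 4 lacks that sulfur atom as well. On that basis a rise is expected, of the step of a number 35 percentage points higher from compound 3 to compound 4 (beyond the scatter), which lies beyond the scatter. For compound 4 the estimate in this assay is 50%, within 20% to 80%.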

Compound 4, percent of the compound remaining: 54%
Estimate against measurement, compound 4: 4 percentage points below; low and high end bracket the measured number.
By their numbers in this assay, from the lowest: compound 3; then compound 4; then compounds 2 and 1 (each within the scatter of the next).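

Among the compounds shown here, with the rest of the molecule unchanged, exchanging one group of 9 heavy atoms for another on the carbonyl carbon gives a number 39 percentage points higher from compound 3 to compound 4 (beyond the scatter) in this assay, so for the first time a gap of this kind can be tied to a single place. The two groups match in heavy-atom count, hydrogen-bond donors, hydrogen-bond acceptors and net charge, and differ in that the entering group has a second nitrogen and no sulfur, with both hetero atoms in its five-membered aromatic ring. No measurement shown here accounts for the step.

As far as these compounds go, it remains open whether the same exchange would give a similar step in compounds with the sulfonyl partner of compound 1. Also open, from the compounds shown here alone, is how a sulfonamide built from dimethylamine would behave with the group of compound 4.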